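The compounds below may be only part of what the source reports. "The series", "measured", "known", "first", "only" and "open" are said of these compounds alone.

Measured in an ADME assay on a cell-free system (plasma, Homo sapiens) for protein binding:

- compound 1 `COc1ccc(F)cc1-c1ccnc2[nH]c(C3=CCC(C(=O)O)CC3)cc12`: 99.8%
- compound 2 `COc1ccc(F)cc1-c1c(F)cnc2[nH]c(C3=CCN([C@H]4CC[C@@H](C(=O)O)CC4)CC3)cc12`: 93.4%

Of these two, compound 2 has the lower binding, at 93.4%, and so the larger unbound fraction. Compound 1, at 99.8%, leaves far less free, and the gap between them lies beyond the usual scatter. The two compounds differ in more than one place, so this gap cannot be traced to a single change.

Compound 3 `COc1ccc(F)cc1-c1c(F)cnc2[nH]c(C3=CCN([C@H]4CC[C@H](C(=O)O)CC4)CC3)cc12` has not yet been measured. Its relation to compound 2 is this: the two compounds have the same atoms and bonds and differ only in configuration as drawn: 2 of 2 stereo elements differ (all stereocentres are inverted: mirror images); a stereocentre at a saturated ring carbon is drawn s in compound 2 and r in compound 3; a stereocentre at a saturated ring carbon is drawn s in compound 2 and r in compound 3. Among the compounds with values here, no measured pair here shows what such a change in configuration does, so compound 2, at 93.4%, is the nearest guide. No clear direction is expected, and the estimated change, a 1.1-fold lower unbound fraction from compound 2 to compound 3 (0.04 log units; within the scatter), stays within the scatter. For compound 3 the expected value is 94%, with an estimated range from 86% to 97.5%.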

Compound 3, plasma protein binding: 94.1%
Compound 3: the middle estimate sits 1.0-fold (0.01 log units) (unbound fraction) above what was measured; measured number inside the range.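

In this assay, the step between the two mirror images is a 1.1-fold lower unbound fraction from compound 2 to compound 3 (0.05 log units; within the scatter), so inverting both stereocentres at the saturated ring carbons leaves plasma protein binding within the scatter. This is the first pair shown that can be compared directly, and the comparison isolates one kind of change: the fact that compounds 2 and 3 differ only in the configuration as drawn

For this pair, then, the configuration as drawn does not separate the two compounds in the fraction left unbound.

The compounds shown still do not assign the much larger gap to compound 1 to any single change in structure. They also leave open what this assay would read if a primary amide or a tetrazole took the place of the carboxylic acid, a group that all the compounds shown carry.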